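Chloro on the aryl ring of an azepane and piperazine pair

This account rests on a few compounds, and the source may have more. Where it says the series, first, only, none or still open, it means among the compounds named here.

Measured compounds: compound 1 `Clc1ccc(-c2n[nH]cc2N2CCCNCC2)cc1`, 1230 nM; compound 2 `c1ccc(-c2n[nH]cc2N2CCCNCC2)cc1`, > 10000 nM; compound 3 `c1ccc(-c2n[nH]cc2N2CCNCC2)cc1`, > 10000 nM.

In an assay on isolated protein for binding affinity to 5-hydroxytryptamine receptor 1D (Homo sapiens) (a lower number here means a stronger inhibitor, a higher number a weaker inhibitor), compound 1 gives 1230 nM. Compound 2 reaches only the limit of this assay, > 10000 nM. Compound 3 likewise sits at the limit, > 10000 nM; the difference between the core of compound 3 and that of compound 2 is not broken down here. The change chloro in place of hydrogen on an aromatic carbon brought an at least 8.1-fold lower number from compound 2 to compound 1 (0.91 log units; beyond the scatter), and this is the same change as chloro in place of hydrogen on an aromatic carbon, which leads to compound 4 `Clc1ccc(-c2n[nH]cc2N2CCNCC2)cc1`, not yet measured in this assay. From compound 3 to compound 4 a step of an at least 3.3-fold lower number from compound 3 to compound 4 (0.52 log units; beyond the scatter) is expected, resting on the step of an at least 8.1-fold lower number from compound 2 to compound 1 (0.91 log units; beyond the scatter). Compound 4 is estimated at 3000 nM, between 800 nM and 20000 nM.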

Compound 4, inhibition constant: > 10000 nM
Compound 4 ended at the assay's limit (the forecaster's own chance of this, stated with the estimate: 40%); at least 3.3-fold (0.52 log units) between middle value and limit.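

The step from compound 3 to compound 4 cannot be read, since both compounds sit at the limit of this assay: the limit of > 10000 nM in this assay, at which 3 of the 4 values shown sit.

From the compounds shown here alone, whether chloro in place of hydrogen lowers the number on the core of compound 3, as it did on the core of compound 2, stays open.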